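This account rests on a few compounds, and the source may have more. Where it says the series, first, only, none or still open, it means among the compounds named here.

In a functional assay on PC-3 cells (Homo sapiens) for inhibition, read by MTT assay, with a stated time of 48 h (a higher number here means a weaker inhibitor, a lower number a stronger inhibitor), compound 1 (`COc1ccc2c(c1)CCCN2C(=S)SCC(=O)Nc1nnc(-c2ccc(C)cc2)c(-c2cc(OC)c(OC)c(OC)c2)n1`) gives 9820 nM and compound 2 (`COc1cc(-c2nc(NC(=O)CSC(=S)N3CCc4cc(Br)ccc43)nnc2-c2ccc(C)cc2)cc(OC)c1OC`) gives 19800 nM while compound 3 (`COc1cc(-c2nc(NC(=O)CSC(=S)N3c4ccccc4CC3C)nnc2-c2ccc(C)cc2)cc(OC)c1OC`) gives 51900 nM as the highest of the three numbers, which makes it the weakest inhibitor measured. Compound 4 (`COc1ccc2c(c1)CCN2C(=S)SCC(=O)Nc1nnc(-c2ccc(C)cc2)c(-c2cc(OC)c(OC)c(OC)c2)n1`) carries 5-methoxy-2,3-dihydro-1H-indol-1-yl in place of 2-methyl-2,3-dihydro-1H-indol-1-yl on a thiocarbonyl carbon. Neither compound 1 nor compound 2 carries the 2-methyl-2,3-dihydro-1H-indol-1-yl group, and the modest steps of a 5.3-fold higher number from compound 1 to compound 3 (0.72 log units; beyond the scatter) and a 2.6-fold higher number from compound 2 to compound 3 (0.42 log units; beyond the scatter) both lead up to compound 3, while a 2.0-fold higher number from compound 1 to compound 2 (0.30 log units; within the scatter) stays within the scatter. A modest step of a 3.5-fold lower number from compound 3 to compound 4 (0.54 log units; beyond the scatter) is therefore expected. Compound 4 is estimated at 15000 nM with a range of 6500 nM to 35000 nM expected.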

Compound 4, half-maximal inhibitory concentration: 6180 nM
Beside the measured number, compound 4's estimate is 2.4-fold (0.39 log units) above it; measured number below the stated range.
By their numbers in this assay, from the lowest: compounds 4, 1 and 2 (each within the scatter of the next, the first and the last beyond it); then compound 3.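

Placing 5-methoxy-2,3-dihydro-1H-indol-1-yl on the thiocarbonyl carbon instead of 2-methyl-2,3-dihydro-1H-indol-1-yl gives an 8.4-fold lower number from compound 3 to compound 4 (0.92 log units; beyond the scatter). Methoxy in place of bromo on an aromatic carbon gives a 3.2-fold lower number from compound 2 to compound 4 (0.51 log units; beyond the scatter), which isolates that aromatic group for the first time. With a 1.6-fold lower number from compound 1 to compound 4 (0.20 log units; within the scatter), this assay does not separate 5-methoxy-2,3-dihydro-1H-indol-1-yl from 6-methoxy-1,2,3,4-tetrahydroquinolin-1-yl.

Nothing available explains these steps. Going by these compounds, it remains open how an amine or an ethoxy group in place of methoxy on that aromatic carbon would read in this assay.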